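The source may report more compounds than this note shows. Statements on the series, on what has been measured and on what is new or still open speak of the compounds shown alone.

In an ADME assay (liver) for metabolic stability, with Liver microsome (Homo sapiens) as the target, read by LC-MS, using microsomes and NADPH, tested at 1 uM (on this read-out lower numbers stand for a shorter-lived compound and higher numbers for a longer-lived compound), compound 1 `CC(C)(C)c1cc(NC(=O)[C@@H]2CCCCN2C2CC2)no1` gives 0.183 h, and compound 2 `CC(C)(C)c1cc(NC(=O)[C@@H]2CCCCN2C2CCOCC2)no1` gives 0.317 h; the step of a 1.7-fold higher number from compound 1 to compound 2 (0.24 log units; within the scatter) stays within the scatter. Compound 3 `CC(C)(C)c1cc(NC(=O)[C@@H]2CCCCN2C(=O)C2CCS(=O)(=O)CC2)no1` gives > 2 h, which is a limit of the assay rather than a number. Compound 3 thus stands at the limit of > 2 h in this assay, at which 1 of the 3 values shown sits. Compound 4 `CC(C)(C)c1cc(NC(=O)[C@@H]2CCCCN2C(=O)N2CC[S+]([O-])CC2)no1` differs from compound 3 by a group of 7 heavy atoms (4 carbon, 1 nitrogen, 1 oxygen, 1 sulfur; one six-membered non-aromatic ring with 2 hetero atoms) in place of a group of 8 heavy atoms (5 carbon, 2 oxygen, 1 sulfur; one six-membered non-aromatic ring with 1 hetero atom), on a carbonyl carbon. Going by the values given here, none of the measured steps touches a carbonyl carbon: the only one, a 1.7-fold higher number from compound 1 to compound 2 (0.24 log units; within the scatter), concerns an amine nitrogen in a ring and lay within the scatter, so it gives no direction beyond the scatter for this change. Compound 4 is therefore expected to remain near the limit, with an estimated step of a number no higher from compound 3 to compound 4 (the limit leaves the size open). Compound 4 is estimated at 2 h, between 0.7 h and 4 h.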

Compound 4, half-life: > 2 h
Compound 4: no number, only a limit; the forecaster's own chance of this, stated with the estimate: 50%; the middle value sits exactly at the limit.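

On the carbonyl carbon, the 1,1-dioxothian-4-yl group can give way to a six-membered ring with 2 hetero atoms, and compound 4 still stands at a limit of this assay, not at a number: the limit of > 2 h in this assay, at which 2 of the 4 values shown sit.

Both compound 3 and compound 4 are limits, so the step between them cannot be read. On the amine nitrogen in a ring, the new group gives an at least 6.3-fold higher number from compound 2 to compound 4 (0.79 log units; beyond the scatter) and an at least 10-fold higher number from compound 1 to compound 4 (1.03 log units; beyond the scatter).

As far as these compounds go, how far past the limit compound 3 and compound 4 lie stays open. From the compounds shown here alone, whether an amine or a carboxylic acid on that carbonyl carbon would also reach the limit stays open too.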